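Chloro to Hydroxy on a Shared Core

The compounds below may be only part of what the source reports. "The series", "measured", "known", "first", "only" and "open" are said of these compounds alone.

Two compounds have been measured in a functional assay on HepG2 cells (Homo sapiens) for antiproliferative activity, read by MTT assay, with a stated time of 48 h; a higher number here means a weaker inhibitor, a lower number a stronger inhibitor:

Compound 1 `COc1ccc(-c2ccc3c(c2)C(=O)C(=O)N3Cc2cc(C)cc(C)c2)cc1` gives 410 nM.
Compound 2 `COc1ccc(CN2C(=O)C(=O)c3cc(-c4ccc(Cl)cc4)ccc32)cc1` gives 380 nM.

Compound 2 carries a 4-chlorophenyl group and a methoxy-bearing benzyl on the shared core, and its number is the lower of the two shown. The difference to compound 1 is small, however, and the two values lie within the scatter of repeated measurements, so nothing separates them. Compound 3 `COc1ccc(CN2C(=O)C(=O)c3cc(-c4ccc(O)cc4)ccc32)cc1` is the next step from compound 2: hydroxy in place of chloro on an aromatic carbon. Put another way, the 4-chlorophenyl becomes a 4-hydroxyphenyl, while the rest of the molecule stays as it is. Going by the values given here, no measured pair shows this change on this core, so the expected size of the step in this assay rests on the change itself. A modest weakening is expected for compound 3, though a result within the scatter of compound 2 would not be surprising, and the estimated step of a 1.7-fold higher number from compound 2 to compound 3 (0.23 log units; within the scatter) reflects that. Compound 3 is therefore expected to give about 650 nM, with a likely range from 250 nM to 1700 nM.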

Compound 3, half-maximal inhibitory concentration: > 10000 nM
Compound 3 ended at the assay's limit; the forecaster's own chance of this, stated with the estimate: 3%; at least 15-fold (1.18 log units) between middle value and limit.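

At this position, para to a large group, the exchange of one heavy atom for another is far from neutral in this assay: hydroxy in place of chloro gives an at least 26-fold higher number from compound 2 to compound 3 (1.42 log units; beyond the scatter), a step beyond the scatter. Going by these compounds alone, compound 3 gives > 10000 nM, which is a limit of the assay and not a number: the limit of > 10000 nM in this assay, at which 1 of the 3 values shown sits. This is the first step between measured compounds that differ in one place, and it shows that activity can depend heavily on the single group at this position, with the entering hydroxy counting one hydrogen-bond donor and one hydrogen-bond acceptor where the chloro counts neither.

The compounds shown cannot say whether the loss follows from the arrival of the hydroxy or from the departure of the chloro, a question that a fluoro, a methyl or an amine at the same position would help to settle. They also leave open how far the step reaches beyond the limit and whether the same change has a similar effect when the methoxy-bearing benzyl is replaced by another group.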